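The source may hold more compounds than are shown below. What is called first, only, known or untested is meant among the compounds shown, and "the series" means these compounds.

Measured compounds:
compound 1, `O=C(/C=C/c1ccc([N+](=O)[O-])cc1)N1CCC=CS1(=O)=O`, 24400 nM
compound 2, `Cc1ccc(C(=O)N2CCC=CS2(=O)=O)cc1[N+](=O)[O-]`, 39300 nM

Of the compounds shown here, two sharing one core have been measured in a functional assay on HeLa cells (Homo sapiens) for inhibition, read by sulforhodamine B assay, with a stated time of 48 h; on this read-out lower numbers stand for stronger inhibition of growth and higher numbers for weaker inhibition of growth. Compound 1 gives 24400 nM, and compound 2 gives 39300 nM. Compound 1 holds the lowest of the two numbers, but the gap to compound 2 lies within the scatter of repeated measurements, so the two stand as equals on this read-out.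

Compound 3, `Cc1ccc(/C=C/C(=O)N2CCC=CS2(=O)=O)cc1`, has not yet been measured in this assay. It differs from compound 1 in one place: methyl in place of nitro on an aromatic carbon. Going by the values given here, no measured pair shows what such a swap does on this core, so there is no step to lean on. Among the compounds with values here, with only two measured values, both close to each other, the step from compound 1 to compound 3 is expected to be small, at most a modest weakening of growth inhibition, and may well stay within the scatter.

On that basis compound 3 is estimated at 35000 nM, with a range of 12000 nM to 100000 nM, which corresponds to an expected step of a 1.4-fold higher number from compound 1 to compound 3 (0.16 log units; within the scatter).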

Compound 3, concentration for 50% growth inhibition: 18600 nM
Estimate against measurement, compound 3: 1.9-fold (0.27 log units) above, and the stated range covers the measured number.
By their numbers in this assay, from the lowest: compounds 3, 1 and 2 (each within the scatter of the next, the first and the last beyond it).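

In this assay, methyl in place of nitro on an aromatic carbon gives a 1.3-fold lower number from compound 1 to compound 3 (0.12 log units; within the scatter) and so stays within the scatter. Going by these compounds alone, this is the first single-place comparison, and it shows that at this position, para to a large group, replacing nitro with methyl, which removes the hydrogen-bond acceptors of the nitro group, does not shift the read-out beyond the scatter. No measurement offered here accounts for this flat result.

Going by these compounds, whether an amine, a carboxylic acid or a longer chain at this position would carry the number beyond the scatter remains open. A single step also cannot show whether the same swap would read alike at any other position on the shared core.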